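Removing the side chain at the amine-bearing position of compound 3

The source may report more compounds than this note shows. Statements on the series, on what has been measured and on what is new or still open speak of the compounds shown alone.

Measured so far in a functional assay (aorta) for antagonist activity, with Oryctolagus cuniculus as the target; on this read-out higher numbers stand for weaker inhibition and lower numbers for stronger inhibition:
- compound 1 `CCCCc1ccc(CNC(=O)OC(C)(C)C)c(=O)n1Cc1ccc(-c2ccccc2-c2nn[nH]n2)cc1`: 10 nM
- compound 2 `CCCCc1ccc(CNS(=O)(=O)c2ccccc2)c(=O)n1Cc1ccc(-c2ccccc2-c2nn[nH]n2)cc1`: 7 nM
- compound 3 `CCCCc1ccc(CN(C(C)C)S(C)(=O)=O)c(=O)n1Cc1ccc(-c2ccccc2-c2nn[nH]n2)cc1`: 0.9 nM

Compound 3 gives the lowest number of the three in this assay. Its nearest neighbour is compound 2, and the step of a 7.8-fold lower number from compound 2 to compound 3 (0.89 log units; beyond the scatter) is beyond the scatter. The step of an 11-fold lower number from compound 1 to compound 3 (1.05 log units; beyond the scatter) is larger still. Between compound 1 and compound 2, the step of a 1.4-fold lower number from compound 1 to compound 2 (0.15 log units; within the scatter) stays within the scatter.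

Compound 4 `CCCCc1cccc(=O)n1Cc1ccc(-c2ccccc2-c2nn[nH]n2)cc1` differs from compound 3 by hydrogen in place of (isopropyl(methylsulfonyl)amino)methyl on an aromatic carbon. Among the compounds with values here, no measured step removes this group altogether; the steps that bear on the question are those in which the group was varied, namely an 11-fold lower number from compound 1 to compound 3 (1.05 log units; beyond the scatter) and a 7.8-fold lower number from compound 2 to compound 3 (0.89 log units; beyond the scatter). Both show that what stands at this position shifts the number by a substantial amount, and that compound 3 carries the form that gives the lowest number among the three. Taking the group away entirely is therefore expected to move the number upward in this assay by a step at least comparable to those two, and the estimated step is a 67-fold higher number from compound 3 to compound 4 (1.82 log units; beyond the scatter). For compound 4 the expected value is 60 nM, with a range from 10 nM to 400 nM.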

Compound 4, half-maximal inhibitory concentration: 4 nM
The estimate for compound 4 lay 15-fold (1.18 log units) above the measured number, and the stated range ends above it.
By their numbers in this assay, from the lowest: compound 3; then compounds 4, 2 and 1 (each within the scatter of the next, the first and the last beyond it).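

In this assay the step of a 4.4-fold higher number from compound 3 to compound 4 (0.65 log units; beyond the scatter) is only modest, so the bare position, with hydrogen on this aromatic carbon, keeps a low number without any (isopropyl(methylsulfonyl)amino)methyl group. The side chain therefore acts as a modest modifier rather than a requirement, and its sign depends on its form: a 1.8-fold lower number from compound 2 to compound 4 (0.24 log units; within the scatter) stays within the scatter, so ((phenylsulfonyl)amino)methyl offers no readable gain over hydrogen, while a 2.5-fold lower number from compound 1 to compound 4 (0.40 log units; beyond the scatter) places ((tert-butoxycarbonyl)amino)methyl on the unfavourable side of hydrogen, leaving compound 3 as the only one of the three side-chain compounds with a number clearly lower than hydrogen gives. No measurement at hand accounts for these differences between the side chains.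

Compound 3 differs from compound 1 and compound 2 in both the nitrogen substituent and the group on the sulfonyl or carbonyl, so the share of the isopropyl and of the methylsulfonyl in its lower number remains unresolved. Also open, on these data alone, is how a free aminomethyl, a carboxylic acid or a longer alkyl chain on this aromatic carbon would compare with hydrogen.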